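From methyl to 2-hydroxyethyl in compound 2

The source may report more compounds than this note shows. Statements on the series, on what has been measured and on what is new or still open speak of the compounds shown alone.

Measured in a functional assay, read by spectrophotometry; a lower number here means that less compound is needed, a higher number that more compound is needed for the effect:
Compound 1 `COc1ccc(-c2cc(=O)c3ccc(OCCCCCN4CCC(C)CC4)cc3o2)cc1`: 31.7 nM
Compound 2 `COc1ccc(-c2cc(=O)c3ccc(OCCCCCCN4CCC(C)CC4)cc3o2)cc1`: 32.6 nM

Compound 2, at 32.6 nM, stands level with compound 1, at 31.7 nM. The two values lie within the scatter of each other. Compound 3 `COc1ccc(-c2cc(=O)c3ccc(OCCCCCCN4CCC(CCO)CC4)cc3o2)cc1` departs from compound 2 by hydroxymethyl in place of hydrogen on a saturated chain carbon bound to a saturated ring carbon, so that methyl becomes 2-hydroxyethyl.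

Among the compounds with values here, only one measured step is available, a 1.0-fold higher number from compound 1 to compound 2 (0.01 log units; within the scatter). It is a change of (4-methylpiperidin-1-yl)methyl for 4-methylpiperidin-1-yl, so it says nothing directly about the new hydroxymethyl. The data hold no measured change at this place, which leaves the size of the effect open and the range wide. No clear direction can be drawn from the data, and only a small move in this assay is expected, within the scatter: a 1.2-fold higher number from compound 2 to compound 3 (0.09 log units; within the scatter). The estimate for compound 3 is 40 nM, with an expected range from 13 nM to 120 nM.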

Compound 3, half-maximal effective concentration: 34.4 nM
The estimate for compound 3 lay 1.2-fold (0.07 log units) above the measured number; the measured number falls inside the stated range.
By their numbers in this assay, from the lowest: compounds 1, 2 and 3 (each within the scatter of the next).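

Within the data shown here, compounds 1 and 2 differed only in the chain, so compound 3 gives the first reading of a change on the piperidine itself. In this assay, the step of a 1.1-fold higher number from compound 2 to compound 3 (0.02 log units; within the scatter) shows that hydroxymethyl in place of hydrogen on this saturated chain carbon leaves the number within the scatter, so 4-(2-hydroxyethyl)piperidin-1-yl stands level with 4-methylpiperidin-1-yl here. The combined change of chain and ring substituent, a 1.1-fold higher number from compound 1 to compound 3 (0.04 log units; within the scatter) in the same assay, also stays within the scatter, and nothing at hand accounts for this flat result.

Going by these compounds, whether the position would tolerate a carboxylic acid or an amine in place of the hydroxyl, or a longer chain carrying the hydroxyl, remains open. Also open, on these data alone, is how 4-(2-hydroxyethyl)piperidin-1-yl reads on the shorter chain of compound 1.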